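Swapping a side chain on compound 1

The compounds below may be only part of what the source reports. "The series", "measured", "known", "first", "only" and "open" are said of these compounds alone.

In a functional assay on SH-SY5Y cells (Homo sapiens) for cytotoxicity, read by MTT assay, with a stated time of 72 h (on this read-out lower numbers stand for stronger inhibition and higher numbers for weaker inhibition), compound 1 `O=C1c2c[n+]([O-])c3ccccc3c2C(=O)c2c1c1ccccc1n2Cc1cn(C[C@H](O)CO)nn1` gives > 1000 nM, which is a limit and not a number. Compound 1 therefore stands at the limit of > 1000 nM in this assay, at which 2 of the 3 values shown sit, with no exact value to start from. Its relative compound 2 `CC1(C)O[C@@H](CO)[C@H](Cn2cc(Cn3c4c(c5ccccc53)C(=O)c3c[n+]([O-])c5ccccc5c3C4=O)nn2)O1` gives > 1000 nM, also a limit. Among the compounds with values here, a second relative, compound 3 `CC1(C)OC[C@H](Cn2cc(Cn3c4c(c5ccccc53)C(=O)c3c[n+]([O-])c5ccccc5c3C4=O)nn2)O1`, gives 820 nM, the only true number so far.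

The next molecule, compound 4 `O=C1c2c[n+]([O-])c3ccccc3c2C(=O)c2c1c1ccccc1n2CCCCN1CCCCC1`, keeps the core of compound 1 but carries a different side chain. The change is 3-(piperidin-1-yl)propyl in place of 1-(2,3-dihydroxypropyl)-1H-1,2,3-triazol-4-yl on a saturated chain carbon bound to an aromatic nitrogen. In effect, a 4-(piperidin-1-yl)butyl chain takes the place of the (1-(2,3-dihydroxypropyl)-1H-1,2,3-triazol-4-yl)methyl group.

The measured steps offer only indirect guidance. They are a step that the two limits leave unreadable from compound 1 to compound 2, an at least 1.2-fold lower number from compound 1 to compound 3 (0.08 log units; that floor lies within the scatter) and an at least 1.2-fold lower number from compound 2 to compound 3 (0.08 log units; that floor lies within the scatter). All three alter only the far end of the side chain, and none removes the five-membered aromatic ring that leaves in compound 4. Within the data shown here, no measured step therefore carries over directly to this much larger exchange.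

The number for compound 3, 820 nM, anchors the expectation, which allows a modest move towards lower numbers with a wide margin. The expected change is an at least 1.6-fold lower number from compound 1 to compound 4 (0.22 log units; that floor lies within the scatter). In this assay, the estimate for compound 4 is 600 nM, with an expected range of 150 nM to 2500 nM.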

Compound 4, half-maximal inhibitory concentration: 230 nM
Estimate against measurement, compound 4: 2.6-fold (0.42 log units) above; low and high end bracket the measured number.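

Earlier changes touched only the far end of the side chain, and the steps that could be read had floors within the scatter. Within the data shown here, replacing the whole group on a saturated chain carbon bound to an aromatic nitrogen now gives the first step beyond the scatter, an at least 4.3-fold lower number from compound 1 to compound 4 (0.63 log units; beyond the scatter). In this assay, this shows that the five-membered aromatic ring and its two hydroxyl groups can leave this position altogether without the number rising; instead, it falls. That step is only a floor and not a full size, because the value for compound 1 is a limit and not a number: the limit of > 1000 nM in this assay, at which 2 of the 4 values shown sit.

Compound 4 changes the ring, the chain length and the end group all at once, so the compounds shown cannot say which of these changes carries the step. A morpholine or a dimethylamino group at the end of the same butyl chain, or a shorter or longer chain still ending in piperidine, would help to pull those changes apart.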